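Methyl on a hydroxy oxygen of compound 1

A few compounds are considered here, and "the series" means these few. Any claim that something is new, unique, unknown or untested is made for them only; others in the source may bear on it.

Measured so far in a functional assay on A549 cells (Homo sapiens) for antiproliferative activity, read by MTT assay, with a stated time of 48 h (a higher number here means a weaker inhibitor, a lower number a stronger inhibitor), as half-maximal inhibitory concentrations:
- compound 1 `O=c1cc(-c2ccccc2)oc2cc(O)c(OCCCN3CCCCC3)c(O)c12`: > 100000 nM (a limit)
- compound 2 `O=c1cc(-c2ccccc2)oc2cc(OCc3ccccc3)c(OCCCCN3CCCCC3)c(O)c12`: 1900 nM

Not yet measured: compound 3 `COc1cc2oc(-c3ccccc3)cc(=O)c2c(O)c1OCCCN1CCCCC1`

In this assay compound 1 gives > 100000 nM as a limit and not a number. Among the measured compounds shown here, compound 2 gives 1900 nM as the only actual number so far.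

Compound 3 differs from compound 1 by methyl in place of hydrogen on an oxygen on an aromatic ring, hydroxy to methoxy: methyl in place of hydrogen on an oxygen on an aromatic ring.

No measured step sizes this change. The expectation of a measurable inhibitory concentration for compound 3 rests on compound 2 at 1900 nM and remains tentative. A moderate gain in potency is expected, with the expected step being an at least 5.0-fold lower number from compound 1 to compound 3 (0.69 log units; beyond the scatter) in this assay.

For compound 3 the estimate is 20000 nM, with an expected range from 4000 nM to 100000 nM.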

Compound 3, half-maximal inhibitory concentration: 17000 nM
Estimate against measurement, compound 3: 1.2-fold (0.07 log units) above, within the range that was stated.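

In this assay compound 1 gives > 100000 nM, which is a limit and not a number. Methyl in place of hydrogen on an oxygen on an aromatic ring, hydroxy to methoxy, gives an at least 5.8-fold lower number from compound 1 to compound 3 (0.76 log units; beyond the scatter), the first change in one place that can be read in this series, and it brings compound 3 to a measurable 17000 nM. This step is only a lower bound on the effect of the change, and its full size cannot be given, because one end of it is a limit: the limit of > 100000 nM in this assay, at which 1 of the 3 values shown sits.

The compounds shown leave open whether an ethyl group on this oxygen would move the number further than methyl does. Also open, going by these compounds, is whether the same change would give a step of similar size with a butyl chain carrying the piperidine in place of the propyl chain.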